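Sulfonyl aryl exchange at the sulfonamide of the shared core

This account rests on a few compounds, and the source may have more. Where it says the series, first, only, none or still open, it means among the compounds named here.

Going by the values given here, compound 2 `COc1ccc(S(=O)(=O)N(C)c2ccc3[nH]c(-c4n[nH]c5ccccc45)cc3n2)c(OC)c1` gives 25900 nM in a functional assay on A549 cells (Homo sapiens) for antiproliferative activity, read by MTT assay, with a stated time of 72 h (on this read-out lower numbers stand for stronger inhibition and higher numbers for weaker inhibition), the highest of the two numbers so far; compound 1 `COc1ccc(S(=O)(=O)N(C)c2ccc3[nH]c(-c4n[nH]c5ccccc45)cc3n2)cc1` gives 24300 nM in this assay, and the step of a 1.1-fold higher number from compound 1 to compound 2 (0.03 log units; within the scatter) falls within the scatter. Compound 3 `CN(c1ccc2[nH]c(-c3n[nH]c4ccccc34)cc2n1)S(=O)(=O)c1cccc([N+](=O)[O-])c1` is not yet measured. It differs from compound 2 in the aryl group on the sulfonyl sulfur: 3-nitrophenyl in place of 2,4-dimethoxyphenyl on a sulfonyl sulfur. Among the compounds with values here, the only measured step touches the same aryl ring, where a 1.1-fold higher number from compound 1 to compound 2 (0.03 log units; within the scatter) shows that a methoxy added to that ring left the number unchanged beyond the scatter. Within the data shown here, no step exchanging the whole aryl group exists, so the expectation rests on that single step. The step from compound 2 to compound 3 is therefore expected to be small, a 1.0-fold lower number from compound 2 to compound 3 (0.02 log units; within the scatter), in no particular direction. Compound 3 is estimated at 25000 nM in this assay, with a range from 8000 nM to 80000 nM.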

Compound 3, half-maximal inhibitory concentration: 20100 nM
For compound 3 the middle estimate is 1.2-fold (0.09 log units) above the measured one; low and high end bracket the measured number.
By their numbers in this assay, from the lowest: compounds 3, 1 and 2 (each within the scatter of the next).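

Exchanging the whole aryl group on the sulfonyl sulfur, and not only adding a methoxy to it, stays within the scatter in this assay: the steps are a 1.3-fold lower number from compound 2 to compound 3 (0.11 log units; within the scatter) and a 1.2-fold lower number from compound 1 to compound 3 (0.08 log units; within the scatter). This read-out therefore does not separate 3-nitrophenyl, 4-methoxyphenyl and 2,4-dimethoxyphenyl at this position, across compound 1, compound 2 and compound 3. No supporting measurement bears on this result.

From the compounds shown here alone, it remains open whether an aryl group carrying an amine or a carboxylic acid, or a longer alkyl chain in place of the aryl group on the sulfonyl sulfur, would shift the number beyond the scatter. The compounds shown also leave open how the number responds to changes elsewhere on the shared core, such as at the sulfonamide nitrogen.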